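The source may report more compounds than this note shows. Statements on the series, on what has been measured and on what is new or still open speak of the compounds shown alone.

Measured in a functional assay on M14 cells (Homo sapiens) for antiproliferative activity, with a stated time of 72 h; a lower number here means a stronger inhibitor, a higher number a weaker inhibitor:
compound 1 `C=CC[C@H]1C[C@]2([C@@H](C)Cc3ccc(OC)c(C(N)=O)c3)OCOC2=CC1=O`: 12 nM
compound 2 `C=CC[C@H]1C[C@]2([C@@H](C)Cc3ccc(OC)c(C#N)c3)OCOC2=CC1=O`: 180 nM

Compound 2 holds the higher of these two numbers, which makes it the weaker inhibitor of the pair. Compound 3 `C=CC[C@H]1C[C@]2([C@@H](C)Cc3ccc(OC)c(O)c3)OCOC2=CC1=O` alters the same aromatic carbon: hydroxy in place of cyano on an aromatic carbon. Within the data shown here, only one measured step bears on this, a 15-fold higher number from compound 1 to compound 2 (1.18 log units; beyond the scatter), and it is large. It shows that this carbon matters, though hydroxy is not carbamoyl, so the guide is thin. Removing the cyano is expected to recover much of that gap in this assay, giving a large move to a lower number. The expected change is a 7.2-fold lower number from compound 2 to compound 3 (0.86 log units; beyond the scatter). For compound 3 the estimated value is 25 nM, with an expected range of 5 nM to 120 nM.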

Compound 3, half-maximal inhibitory concentration: 8 nM
Estimate against measurement, compound 3: 3.1-fold (0.49 log units) above; the measured number falls inside the stated range.
By their numbers in this assay, from the lowest: compounds 3 and 1 (each within the scatter of the next); then compound 2.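

In this assay, hydroxy in place of cyano gives a 23-fold lower number from compound 2 to compound 3 (1.35 log units; beyond the scatter), so the weak result with cyano does not extend to every replacement on this aromatic carbon. Hydroxy and carbamoyl cannot be told apart here, with a 1.5-fold lower number from compound 1 to compound 3 (0.18 log units; within the scatter), so a low number at this position does not depend on carbamoyl specifically. Nothing available explains why cyano stands apart from these two groups. Going by these compounds, whether an amine or a carboxylic acid on this carbon would match hydroxy and carbamoyl or fall nearer cyano remains open.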